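The source may report more compounds than this note shows. Statements on the series, on what has been measured and on what is new or still open speak of the compounds shown alone.

Working notes on the trifluoromethyl-benzylamide series, which keeps one shared core and varies the group on an aromatic carbon of the benzyl ring. In an assay on CHO cells for antagonist activity at transient receptor potential cation channel subfamily V member 1 (Homo sapiens), read by FLIPR (a higher number here means a weaker inhibitor, a lower number a stronger inhibitor), compound 1 `CC1CCN(c2cc(C(F)(F)F)ccc2CNC(=O)C(C)c2ccc(NS(C)(=O)=O)c(F)c2)CC1` gives 0.9 nM. Compound 2 `CCCOc1cc(C(F)(F)F)ccc1CNC(=O)C(C)c1ccc(NS(C)(=O)=O)c(F)c1` gives 2 nM, and compound 3 `CC(C(=O)NCc1ccc(C(F)(F)F)cc1SC1CCCC1)c1ccc(NS(C)(=O)=O)c(F)c1` gives 0.3 nM. The measured steps are a 2.2-fold higher number from compound 1 to compound 2 (0.35 log units; beyond the scatter), a 3.0-fold lower number from compound 1 to compound 3 (0.48 log units; beyond the scatter) and a 6.7-fold lower number from compound 2 to compound 3 (0.82 log units; beyond the scatter). Compound 3 therefore holds the lowest number of the three, and both of its gaps to the others lie beyond the scatter.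

Compound 4 `CC(C(=O)NCc1ccc(C(F)(F)F)cc1SCc1ccco1)c1ccc(NS(C)(=O)=O)c(F)c1` keeps the sulfur of compound 3 and alters what sits on it: (furan-2-yl)methyl in place of cyclopentyl on a sulfur. Going by the values given here, no measured step changes a group on the sulfur; each exchanges the whole substituent on the aromatic carbon, so the three steps show only that a cyclopentylsulfanyl group gives the lowest number seen and that every exchange so far has been modest in size. A modest step of similar size, toward a higher number, is expected, a 2.0-fold higher number from compound 3 to compound 4 (0.30 log units; within the scatter). Compound 4 is therefore estimated at 0.6 nM in this assay, within a range of 0.2 nM to 2 nM.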

Compound 4, inhibition constant: 3.2 nM
Estimate against measurement, compound 4: 5.3-fold (0.73 log units) below, and the stated range ends below it.
By their numbers in this assay, from the lowest: compound 3; then compound 1; then compounds 2 and 4 (each within the scatter of the next).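

Going by these compounds alone, on the sulfur the choice of group counts heavily: in this assay, an 11-fold higher number from compound 3 to compound 4 (1.03 log units; beyond the scatter) is the largest step so far, and it arises with the sulfur kept in place. The low number of compound 3 therefore does not follow from a sulfanyl group as such, since ((furan-2-yl)methyl)sulfanyl gives a 3.6-fold higher number from compound 1 to compound 4 (0.55 log units; beyond the scatter), beyond the scatter, while a 1.6-fold higher number from compound 2 to compound 4 (0.20 log units; within the scatter) stays within the scatter, leaving it no different from propoxy on this evidence. Nothing measured here accounts for the size of the step on the sulfur.

The exchange changes the ring and its link to the sulfur together, so the compounds shown do not separate the two; cyclopentylmethyl on the sulfur would. Also open, on these data alone, is what the sulfur itself contributes, which cyclopentyloxy on the aromatic carbon would test directly against compound 3.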